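The source may hold more compounds than are shown below. What is called first, only, known or untested is meant among the compounds shown, and "the series" means these compounds.

Series notes, shared core of compound 1 `Cc1cc(COc2cccc(F)c2)nc(-c2ccccn2)n1` with compound 2 `CN(C)c1cc(COc2cccc(F)c2)nc(-c2ccccn2)n1` and the still unmeasured compound 3 `CC(C)Nc1cc(COc2cccc(F)c2)nc(-c2ccccn2)n1`. In a functional assay on cells for antagonist activity at Free fatty acid receptor 1 (Homo sapiens), read by TR-FRET and inositol phosphate accumulation, with a stated time of 2 h (on this read-out lower numbers stand for stronger inhibition and higher numbers for weaker inhibition), compound 1 gives 794 nM, and in this assay compound 2 gives 1580 nM. For the measured compounds named here, of the two values so far, compound 2 holds the higher number, yet the step of a 2.0-fold higher number from compound 1 to compound 2 (0.30 log units; within the scatter) lies within the scatter, so the pair is not separated. The change now followed is isopropylamino in place of dimethylamino on an aromatic carbon. Going by the values given here, no measured step exchanges one amino substituent for another; the single reference point, dimethylamino for methyl, a 2.0-fold higher number from compound 1 to compound 2 (0.30 log units; within the scatter), was small. The exchange of dimethylamino for isopropylamino is therefore expected to leave this assay essentially unchanged, with the estimated step of a 1.1-fold lower number from compound 2 to compound 3 (0.05 log units; within the scatter) staying within the scatter. Compound 3 is expected in this assay at about 1400 nM, with a range from 500 nM to 4000 nM.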

Compound 3, half-maximal inhibitory concentration: 100 nM
Compound 3: middle estimate off by 14-fold (1.15 log units), on the high side; measured number below the stated range.
By their numbers in this assay, from the lowest: compound 3; then compounds 1 and 2 (each within the scatter of the next).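

In this assay, this position on the shared core responds strongly to which amino group it carries: isopropylamino in place of dimethylamino gives a 16-fold lower number from compound 2 to compound 3 (1.20 log units; beyond the scatter), although the earlier change from methyl to dimethylamino stayed within the scatter. Isopropylamino in place of methyl gives a 7.9-fold lower number from compound 1 to compound 3 (0.90 log units; beyond the scatter), so compound 3 stands apart from both compound 1 and compound 2, and the entering group differs from dimethylamino in having 1 hydrogen-bond donor rather than 0 and 4 heavy atoms rather than 3. No measurement available here accounts for the step.

Compound 3 alone cannot show whether the amine hydrogen or the branched isopropyl group matters, and an unbranched ethylamino group or a plain amino group would help separate the two. As far as these compounds go, it also remains open how a longer chain, such as butylamino, or a cyclic amine, such as morpholine, would read at this position.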